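Swapping a six-membered lactam for an exocyclic five-membered one

The compounds below may be only part of what the source reports. "The series", "measured", "known", "first", "only" and "open" are said of these compounds alone.

Measured so far in an assay on CHO cells for displacement of a labelled ligand from prostaglandin E2 receptor EP3 subtype (Homo sapiens), read by radioligand binding; on this read-out higher numbers stand for weaker inhibition and lower numbers for stronger inhibition:
- compound 1 `CCC(CC)(c1nnc[nH]1)c1ccc(-c2ccc3cc(F)cc(F)c3c2)[nH]c1=O` gives 89 nM
- compound 2 `CCn1ncc2c(F)cc(-c3ccc(C(CC)(CC)c4nnc[nH]4)c(=O)[nH]3)cc21` gives 17 nM
- compound 3 `CC(C)C(c1ccc(-c2ccc3cccc(F)c3c2)[nH]c1=O)N1CCCCC1=O` gives 6.4 nM

Compound 3 has the lowest number of the three, so it is the strongest binder in this set. Compound 2 is nearest to it and compound 1 furthest, and both gaps lie beyond the usual scatter of repeated measurements.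

Compound 4 `CC(C)C(/C=C1\CCNC1=O)c1ccc(-c2ccc3cccc(F)c3c2)[nH]c1=O` has not been measured. It differs from compound 3 in one place: a group of 7 heavy atoms (5 carbon, 1 nitrogen, 1 oxygen; one five-membered non-aromatic ring with 1 hetero atom) in place of a group of 7 heavy atoms (5 carbon, 1 nitrogen, 1 oxygen; one six-membered non-aromatic ring with 1 hetero atom), on a saturated chain carbon bound to an aromatic carbon and a saturated chain carbon. The count of heavy atoms stays the same, while the ring shrinks and the new group carries a hydrogen-bond donor that the old one lacked.

Among the measured compounds shown here, no pair of measured compounds shows what this kind of exchange does, so the expectation rests on compound 3 alone. A modest step upward, that is toward weaker inhibition, is expected for compound 4, of the size a 2.3-fold higher number from compound 3 to compound 4 (0.37 log units; beyond the scatter), with a wide range. Compound 4 is therefore estimated at 15 nM in this assay, between 4 nM and 60 nM.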

Compound 4, inhibition constant: 2.2 nM
Compound 4: the middle estimate sits 6.8-fold (0.83 log units) above what was measured, outside the stated range (below it).
By their numbers in this assay, from the lowest: compound 4; then compound 3; then compound 2; then compound 1.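

In this assay, replacing the 2-oxopiperidin-1-yl group with the five-membered lactam gives a 2.9-fold lower number from compound 3 to compound 4 (0.46 log units; beyond the scatter), so the saturated chain carbon bound to an aromatic carbon and a saturated chain carbon accepts a quite different lactam group, and binding is not lost but improves. This single exchange shrinks the ring, adds a double bond outside aromatic rings and brings in a hydrogen-bond donor all at once, so the step cannot be assigned to any one of these changes. Nothing measured on these compounds speaks to the reason for the step.

Going by these compounds, a 2-oxopyrrolidin-1-yl group at this position would change the ring size while keeping the attachment through nitrogen, and its result remains open here. Also open, on these data alone, is how a saturated two-carbon link to the five-membered lactam, without the double bond, would compare.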